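The compounds below may be only part of what the source reports. "The series", "measured", "known", "first", "only" and "open" are said of these compounds alone.

In a functional assay on K562 cells (Homo sapiens) for cytotoxicity, read by fluorescence, with a stated time of 72 h (a lower number here means a stronger inhibitor, a higher number a weaker inhibitor), two compounds sharing one core have been measured so far. Compound 1 `CC(C)c1n[nH]c2c(NCc3ccc(-c4ccccn4)cc3)nc(NCCO)nc12`, which carries (2-hydroxyethyl)amino, gives 38 nM. Compound 2 `CC(C)c1n[nH]c2c(NCc3ccc(-c4ccccn4)cc3)nc(N3CCNCC3)nc12`, which carries piperazin-1-yl at the same place, gives 17 nM, the lower of the two numbers. The measured step, a 2.2-fold lower number from compound 1 to compound 2 (0.35 log units; beyond the scatter), is modest but beyond the scatter.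

Among the compounds with values here, compound 3 `CC(C)c1n[nH]c2c(NCc3ccc(-c4ccccn4)cc3)nc(NCCN(C)C)nc12` keeps the core and alters only that group, on an aromatic carbon between two ring nitrogen atoms: (2-(dimethylamino)ethyl)amino in place of piperazin-1-yl on an aromatic carbon. Within the data shown here, the single measured step is the only evidence that bears on this change, and no measurement yet covers (2-(dimethylamino)ethyl)amino itself. The entering group has no ring, and neither does the group of compound 1, which stands at 38 nM. A move toward that higher number is therefore expected, though probably a smaller one than the measured step, and it may stay within the scatter. The estimated step is a 1.5-fold higher number from compound 2 to compound 3 (0.17 log units; within the scatter). For compound 3 the estimated value is 25 nM, with an expected range from 10 nM to 60 nM.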

Compound 3, half-maximal inhibitory concentration: 125 nM
Beside the measured number, compound 3's estimate is 5.0-fold (0.70 log units) below it; measured number outside the range, above it.
By their numbers in this assay, from the lowest: compound 2; then compound 1; then compound 3.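

In this assay the exchange of piperazin-1-yl for (2-(dimethylamino)ethyl)amino gives a 7.4-fold higher number from compound 2 to compound 3 (0.87 log units; beyond the scatter) even though the heavy atoms, hydrogen-bond donors and hydrogen-bond acceptors counted for the two groups are the same, and the ring that leaves is the only counted difference between them. Losing that ring does not alone set the number, since compound 1 and compound 3 both have an open chain at this place and dimethylamino in place of hydroxy on the saturated chain carbon still gives a 3.3-fold higher number from compound 1 to compound 3 (0.52 log units; beyond the scatter) as a separate step. The three compounds therefore show that this position distinguishes both the ring from the open chain and one end group of the chain from another, though nothing measured here explains either difference.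

The compounds shown leave open whether the higher number of compound 3 would persist with a longer chain, such as (3-(dimethylamino)propyl)amino, or with a dimethylamino group carried on a ring. They also leave open how far the ring nitrogen matters, which morpholin-4-yl or 4-methylpiperazin-1-yl at the same place could test.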